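Swapping the aryl group on the triazole nitrogen

The source may hold more compounds than are shown below. What is called first, only, known or untested is meant among the compounds shown, and "the series" means these compounds.

Two compounds share a core in which a cinnamic acid fragment is linked through an ether to a triazole that carries an aryl group on one of its nitrogens. Compound 1 `COc1ccccc1-n1cc(COc2c(/C=C\C(=O)O)ccc(OC)c2CC=C(C)C)nn1` bears a 2-methoxyphenyl group there, and in a functional assay on NCI-H322 cells (Homo sapiens) for cytotoxicity, read by MTT assay, with a stated time of 24 h (on this read-out higher numbers stand for weaker inhibition and lower numbers for stronger inhibition), compound 1 gives 41500 nM. Compound 2 `COc1ccc(/C=C\C(=O)O)c(OCc2cn(-c3cccnc3Cl)nn2)c1CC=C(C)C` carries a 2-chloropyridin-3-yl group instead, and in this assay compound 2 gives 42200 nM. The step of a 1.0-fold higher number from compound 1 to compound 2 (0.01 log units; within the scatter) shows that this exchange left the read-out essentially unchanged. Compound 2 thus holds the highest of the two numbers, but its nearest neighbour, compound 1, lies within the scatter of it, so no order between the two can be drawn.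

Compound 3 `COc1ccc(/C=C\C(=O)O)c(OCc2cn(-c3nc4ccccc4s3)nn2)c1CC=C(C)C` differs from compound 2 in the same position: 1,3-benzothiazol-2-yl in place of 2-chloropyridin-3-yl on an aromatic nitrogen. Among the measured compounds shown here, the only step that bears on this change is a 1.0-fold higher number from compound 1 to compound 2 (0.01 log units; within the scatter), which replaced one aryl group on that nitrogen with another and stayed within the scatter. On that basis a step of comparable size, that is none beyond the scatter, is expected in this assay for compound 3, namely a 1.0-fold lower number from compound 2 to compound 3 (0.00 log units; within the scatter). Compound 3 is therefore estimated at 42000 nM, with a range from 15000 nM to 120000 nM.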

Compound 3, half-maximal inhibitory concentration: 23000 nM
Beside the measured number, compound 3's estimate is 1.8-fold (0.26 log units) above it, and the stated range covers the measured number.
By their numbers in this assay, from the lowest: compounds 3, 1 and 2 (each within the scatter of the next).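

Replacing the earlier aryl groups with 1,3-benzothiazol-2-yl in this assay gives a 1.8-fold lower number from compound 2 to compound 3 (0.26 log units; within the scatter) and a 1.8-fold lower number from compound 1 to compound 3 (0.26 log units; within the scatter), and both steps stay within the scatter. The earlier pair compared only groups with a single six-membered aromatic ring, so this result extends the picture: the aromatic nitrogen also accepts a group with one five-membered aromatic ring and one six-membered aromatic ring of carbon only, without a step beyond the scatter, and the group that enters brings sulfur and no chlorine. Nothing available accounts for the size of these steps or connects them to a measured property of the groups.

As far as these compounds go, all three compounds carry an aromatic ring directly on this nitrogen, so it remains open whether a group of another kind there, such as a simple alkyl chain, a benzyl group or a chain ending in an amine, would move the number beyond the scatter. From the compounds shown here alone, it also remains open whether the same flat picture would hold if the carboxylic acid of the shared core were replaced by a methyl ester.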